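Bromo to Methyl at the Para Position of a Pyrazoline Thiourea

A few compounds are considered here, and "the series" means these few. Any claim that something is new, unique, unknown or untested is made for them only; others in the source may bear on it.

Measured compounds:
Compound 1, `S=C(Nc1ccccc1)N1N=C(c2ccccc2)CC1c1ccc2c(c1)OCCO2`, 57600 nM
Compound 2, `S=C(Nc1ccccc1)N1N=C(c2ccc(Br)cc2)CC1c1ccc2c(c1)OCCO2`, 32100 nM

For the measured compounds named here, in a functional assay on HCT-116 cells (Homo sapiens) for antiproliferative activity, read by MTT assay, with a stated time of 48 h (a higher number here means a weaker inhibitor of growth, a lower number a stronger inhibitor of growth), compound 2 gives 32100 nM, the lower of the two numbers measured so far. Going by the values given here, its only measured neighbour is compound 1, which in this assay gives 57600 nM, and the step of a 1.8-fold lower number from compound 1 to compound 2 (0.25 log units; within the scatter) stays within the scatter. Compound 3, `Cc1ccc(C2=NN(C(=S)Nc3ccccc3)C(c3ccc4c(c3)OCCO4)C2)cc1`, differs from compound 2 only in methyl in place of bromo on an aromatic carbon. Among the compounds with values here, the one measured step that bears on this position, the exchange of hydrogen for bromo from compound 1 to compound 2, was small, and no measured step speaks to methyl at this place. The expectation for compound 3 is therefore a step of a 1.2-fold higher number from compound 2 to compound 3 (0.10 log units; within the scatter), not beyond the scatter in either direction. Compound 3 is estimated at 40000 nM, with a range from 15000 nM to 110000 nM.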

Compound 3, concentration for 50% growth inhibition: > 200000 nM
Compound 3: only a limit was reported; the forecaster's own chance of this, stated with the estimate: 10%; at least 5.0-fold (0.69 log units) between middle value and limit.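

In this assay compound 3 gives no number, only a limit: the limit of > 200000 nM in this assay, at which 1 of the 3 values shown sits. Read against that limit, methyl in place of bromo gives an at least 6.2-fold higher number from compound 2 to compound 3 (0.79 log units; beyond the scatter), and methyl in place of hydrogen gives an at least 3.4-fold higher number from compound 1 to compound 3 (0.54 log units; beyond the scatter), so both steps lie beyond the scatter. The earlier pair showed only a 1.8-fold lower number from compound 1 to compound 2 (0.25 log units; within the scatter), which gave no sign that this place on the ring mattered; the 4-methylphenyl compound now shows that it does, with growth inhibition weaker than with either hydrogen or bromo there.

On these data alone, how far compound 3 lies past its limit stays unknown, so both steps have a lower bound and no true size. As far as these compounds go, whether a chloro, a methoxy or an amine at this place would behave like bromo or like methyl also remains open.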